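The compounds below may be only part of what the source reports. "The series", "measured", "known", "first", "only" and "open" are said of these compounds alone.

Measured compounds:
- compound 1 `CC(=O)C[C@H]1O[C@@H](On2cc(CN3C(=O)/C(=N\Nc4ccccc4)c4ccccc43)nn2)[C@H](OC(C)=O)[C@@H](OC(C)=O)[C@@H]1OC(C)=O`: 108000 nM
- compound 2 `CC(=O)C[C@H]1O[C@@H](On2cc(CN3C(=O)/C(=N\Nc4ccc(Br)cc4)c4ccccc43)nn2)[C@H](OC(C)=O)[C@@H](OC(C)=O)[C@@H]1OC(C)=O`: 116000 nM
- compound 3 `COc1ccc(N/N=C2\C(=O)N(Cc3cn(O[C@@H]4O[C@H](CC(C)=O)[C@@H](OC(C)=O)[C@H](OC(C)=O)[C@H]4OC(C)=O)nn3)c3ccccc32)cc1`: 95300 nM

In an ADME assay on Vero cells (Chlorocebus sabaeus) for cytotoxicity, read by fluorescence and resazurin assay, with a stated time of 3 days (a higher number here means that more compound is tolerated, a lower number that less compound is tolerated), compound 1 gives 108000 nM. Its nearest neighbour is compound 2, and the step of a 1.1-fold higher number from compound 1 to compound 2 (0.03 log units; within the scatter) is within the scatter; the step of a 1.1-fold lower number from compound 1 to compound 3 (0.05 log units; within the scatter) is also within the scatter, as is a 1.2-fold lower number from compound 2 to compound 3 (0.09 log units; within the scatter). So the three measured compounds cannot be told apart on tolerated concentration, and compound 1 is neither better nor worse tolerated than the others.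

Compound 4 `CC(=O)C[C@H]1O[C@@H](On2cc(CN3C(=O)/C(=N\Nc4ccccc4)c4ccccc43)nn2)[C@H](OC(C)=O)[C@@H](OC(C)=O)[C@H]1OC(C)=O` has not been measured. Compared with compound 1, (the two compounds have the same atoms and bonds and differ only in configuration as drawn: 1 of 6 stereo elements differ; a stereocentre at a saturated ring carbon is drawn R in compound 1 and S in compound 4). Going by the values given here, none of the measured steps concerns a change of configuration; all three concern a substituent on an aromatic carbon, and all three were within the scatter. Among the compounds with values here, there is therefore no measured step that bears on this change, and no basis for expecting a step beyond the scatter in this assay in either direction. The value of compound 4 is estimated at 108000 nM, within 55000 nM to 215000 nM, which means an expected step of no change at the digits printed from compound 1 to compound 4 (within the scatter).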

Compound 4, half-maximal cytotoxic concentration: 65200 nM
Compound 4: the middle estimate sits 1.7-fold (0.22 log units) above what was measured, and the stated range covers the measured number.
By their numbers in this assay, from the lowest: compounds 4, 3, 1 and 2 (each within the scatter of the next).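

In this assay, the change of configuration at this saturated ring carbon comes to a 1.7-fold lower number from compound 1 to compound 4 (0.22 log units; within the scatter). Going by these compounds alone, the earlier steps concerned only substituents on an aromatic carbon, so this is the first reading from the saturated ring, and it shows that redrawing this one stereocentre from R to S has no effect that can be separated from the scatter. The pair gives a clean reading of this stereocentre, as no other structural change is present: the fact that compounds 1 and 4 differ only in the configuration as drawn.

Going by these compounds, whether the other stereocentres are equally forgiving remains open, as does whether S at this carbon would give the same result alongside the bromo or methoxy group. The compounds shown also leave open how a free hydroxyl in place of an acetate, or an amine on the aromatic ring, would read in this assay.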